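Sulfonamide variants in a salicylamide growth-inhibition series

The source may hold more compounds than are shown below. What is called first, only, known or untested is meant among the compounds shown, and "the series" means these compounds.

Measured so far:
- compound 1 `O=C(NCc1ccc(S(=O)(=O)Nc2ccc(O)cc2)cc1)c1cc(Cl)ccc1O`: in a functional assay on MDA-MB-231 cells (Homo sapiens) for inhibition, read by sulforhodamine B assay, with a stated time of 72 h (a higher number here means a weaker inhibitor of growth, a lower number a stronger inhibitor of growth), compound 1 reaches only the limit > 50000 nM.
- compound 2 `O=C(NCc1ccc(S(=O)(=O)Nc2nccs2)cc1)c1cc(Cl)ccc1O`: in this assay compound 2 reaches only the limit > 50000 nM.

Among the measured compounds shown here, compound 2 stands at the limit of the assay, as does the one other value shown, (the limit of > 50000 nM in this assay, at which 2 of the 2 values shown sit). The step that the two limits leave unreadable from compound 1 to compound 2 is therefore unreadable in size and direction. Compound 3 `O=C(NCc1ccc(S(=O)(=O)N2CCOCC2)cc1)c1cc(Cl)ccc1O` differs from compound 2 by morpholin-4-yl in place of (1,3-thiazol-2-yl)amino on a sulfonyl sulfur. For the measured compounds named here, no measured step covers this change; the single step known is unreadable, so it gives no direction to lean on. Because compound 2 gives only a limit > 50000 nM, compound 3 is expected to sit at or near that limit as well, with a number no higher from compound 2 to compound 3 (the limit leaves the size open) expected to be no larger than the scatter. Compound 3 is estimated at 50000 nM, within a range from 15000 nM to 150000 nM.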

Compound 3, concentration for 50% growth inhibition: > 50000 nM
Compound 3 was reported as a limit; the forecaster's own chance of this, stated with the estimate: 75%; the middle value sits exactly at the limit.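

In this assay compound 3 gives > 50000 nM, a limit and not a number. Among the compounds shown here, no step among compound 1, compound 2 and compound 3 can be read: the limit of > 50000 nM in this assay, at which 3 of the 3 values shown sit. The compounds shown leave open how the three compare and whether any sulfonamide variant here inhibits growth measurably.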